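The compounds below may be only part of what the source reports. "The series", "measured", "known", "first", "only" and "open" are said of these compounds alone.

Measured values in a functional assay on HepG2 cells (Homo sapiens) for inhibition, read by MTT assay, with a stated time of 120 h (on this read-out higher numbers stand for weaker inhibition and lower numbers for stronger inhibition), follow
Compound 1 `CNC(=O)/C=C/c1ccc(NC(=O)Nc2ccc(Cl)c(C(F)(F)F)c2)cc1` gives 20400 nM
Compound 2 `CC(NC(=O)CCc1ccc(NC(=O)Nc2ccc(Cl)c(C(F)(F)F)c2)cc1)c1ccccc1` gives > 50000 nM (a limit)
Compound 3 `CNC(=O)c1cccc(-c2ccc(NC(=O)Nc3ccc(Cl)c(C(F)(F)F)c3)cc2)c1` gives 37100 nM

For the measured compounds named here, compound 3 cannot be set apart from compound 1, the only other true number. Compound 2 gives > 50000 nM as a limit of the assay, not a number. Compound 4 `CNC(=O)CCc1ccc(NC(=O)Nc2ccc(Cl)c(C(F)(F)F)c2)cc1` changes one group of compound 3: 2-(methylcarbamoyl)ethyl in place of 3-(methylcarbamoyl)phenyl on an aromatic carbon, para to a large group (2-(methylcarbamoyl)ethyl in place of 3-(methylcarbamoyl)phenyl on an aromatic carbon). Going by the values given here, the one measured step at such a carbon brought 3-(methylcarbamoyl)phenyl in, and it was small (a 1.8-fold higher number from compound 1 to compound 3 (0.26 log units; within the scatter)). So in this assay no step beyond the scatter is expected, in either direction. The estimated step is small too (a 1.3-fold lower number from compound 3 to compound 4 (0.12 log units; within the scatter)). Compound 4 is expected near 28000 nM by this estimate, with an estimated range from 12000 nM to 50000 nM around it.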

Compound 4, half-maximal inhibitory concentration: 21000 nM
Compound 4: middle estimate off by 1.3-fold (0.12 log units), on the high side, within the range that was stated.
By their numbers in this assay, from the lowest: compounds 1, 4 and 3 (each within the scatter of the next). At a limit, above all of these: compound 2.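

In this assay, the three chains tried at this aromatic carbon cannot be told apart: 2-(methylcarbamoyl)ethyl in place of 3-(methylcarbamoyl)phenyl gives a 1.8-fold lower number from compound 3 to compound 4 (0.25 log units; within the scatter), and in place of 2-(methylcarbamoyl)ethenyl it gives a 1.0-fold higher number from compound 1 to compound 4 (0.01 log units; within the scatter). For the compounds shown here, the amide-type nitrogen of this chain shows the only step beyond the scatter, with methyl in place of 1-phenylethyl giving an at least 2.3-fold lower number from compound 2 to compound 4 (0.37 log units; beyond the scatter). Compound 2 stands at a limit, not a number: the limit of > 50000 nM in this assay, at which 1 of the 4 values shown sits.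

Going by these compounds, whether a chain ending in an amine or a carboxylic acid at this carbon would move the number beyond the scatter stays open. So does the effect of an ethyl group on the amide-type nitrogen.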